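The source may report more compounds than this note shows. Statements on the series, on what has been measured and on what is new or still open speak of the compounds shown alone.

Compound 3 `Cc1nnc(SCC(=O)N/N=c2/scc(-c3ccc(C#N)cc3)n2-c2ccccc2)s1` carries the 4-cyanophenyl group on the shared core. In an ADME assay on NIH3T3 cells (Mus musculus) for cytotoxicity, read by MTT assay, with a stated time of 24 h (a lower number here means a stronger inhibitor, a higher number a weaker inhibitor), compound 3 gives only a limit, < 3.9 ug/mL. That limit is the limit of < 3.9 ug/mL in this assay, at which 1 of the 3 values shown sits, so where compound 3 stands among the measured compounds is known only as a bound. Compound 2 `Cc1nnc(SCC(=O)N/N=c2/scc(-c3ccc([N+](=O)[O-])cc3)n2-c2ccccc2)s1`, the nitro analogue on the same core, gives 177 ug/mL in this assay. Among the compounds with values here, the one measured step that reaches compound 3 is an at least 45-fold lower number from compound 2 to compound 3 (1.65 log units; beyond the scatter). Compound 1 `O=C(CSc1nnnn1-c1ccccc1)N/N=c1/scc(-c2ccc(Br)cc2)n1-c1ccccc1`, which carries the bromo group on its aromatic ring but a different thioether substituent, gives 433 ug/mL in this assay.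

Compound 4 `Cc1nnc(SCC(=O)N/N=c2/scc(-c3ccc(Br)cc3)n2-c2ccccc2)s1` is the unmeasured member; the change from compound 3 is bromo in place of cyano on an aromatic carbon. Within the data shown here, no measured step covers bromo in place of cyano on this core. The step from compound 2 to compound 3 shows that exchanging the group on the six-membered aromatic ring alone can move the number far, and compound 1, with the bromo group, sits at 433 ug/mL. Compound 4 is therefore expected to give a higher number, the expected step being an at least 38-fold higher number from compound 3 to compound 4 (1.58 log units; beyond the scatter). Compound 4 is estimated at 150 ug/mL, with a range from 20 ug/mL to 450 ug/mL.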

Compound 4, half-maximal inhibitory concentration: 55 ug/mL
Compound 4: the middle estimate sits 2.7-fold (0.44 log units) above what was measured, within the range that was stated.
By their numbers in this assay, from the lowest: compound 4; then compound 2; then compound 1. At a limit, below all of these: compound 3.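

In this assay, the change from 4-cyanophenyl to 4-bromophenyl on the shared core gives an at least 14-fold higher number from compound 3 to compound 4 (1.14 log units; beyond the scatter), a step that is only a bound, as compound 3 has a limit and not a number: the limit of < 3.9 ug/mL in this assay, at which 1 of the 4 values shown sits. Bromo in place of nitro on the same aromatic carbon gives a 3.2-fold lower number from compound 2 to compound 4 (0.51 log units; beyond the scatter), which is modest, so on this core the bromo and nitro compounds both stay well clear of the cyano compound's limit, and the large shift seen so far belongs to cyano alone among these three groups. With the bromo group held fixed, 5-methyl-1,3,4-thiadiazol-2-yl in place of 1-phenyl-1H-tetrazol-5-yl on the sulfur gives a 7.9-fold lower number from compound 1 to compound 4 (0.90 log units; beyond the scatter), which shows that the thioether substituent also moves the number, and that compound 1 could not stand in directly for the bromo member of this core.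

The compounds shown leave open how large the cyano step really is, and whether any other group on this aromatic carbon, such as an amine, a carboxylic acid or a methoxy group, would fall near cyano or near bromo and nitro. They also leave open whether the change on the sulfur has a similar size when cyano or nitro sits on the ring.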